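Swapping Chloro for Fluoro on Two Related Cores

A few compounds are considered here, and "the series" means these few. Any claim that something is new, unique, unknown or untested is made for them only; others in the source may bear on it.

Measured so far:
compound 1, `O=C1C=C(Nc2cccc(F)c2)C(=O)c2c1nc1n2[C@H]2OC[C@@H](O)[C@H]2OC1`, gives 5500 nM in a functional assay on MCF7 cells (Homo sapiens) for inhibition, read by sulforhodamine B assay; on this read-out lower numbers stand for stronger inhibition and higher numbers for weaker inhibition
compound 2, `O=C1C=C(Nc2cccc(Cl)c2)C(=O)c2c1nc1n2[C@H]2OC[C@@H](O)[C@H]2OC1`, gives 4720 nM in this assay
compound 3, `O=C1C(Nc2cccc(Cl)c2)=CC(=O)c2c1nc1n2[C@H]2OC[C@@H](O)[C@H]2OC1`, gives 2970 nM in this assay

Compound 2 and compound 1 share one core and differ only in the halogen on the aniline ring: fluoro in place of chloro on an aromatic carbon. That exchange moved the read-out by a 1.2-fold higher number from compound 2 to compound 1 (0.07 log units; within the scatter). Compound 3 carries the same atoms as compound 2 joined differently; the difference between the two cores is not broken down here. Their two values, 2970 nM for compound 3 and 4720 nM for compound 2, lie within the scatter of each other.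

The unmeasured compound 4, `O=C1C(Nc2cccc(F)c2)=CC(=O)c2c1nc1n2[C@H]2OC[C@@H](O)[C@H]2OC1`, is built from compound 3 by the same change: fluoro in place of chloro on an aromatic carbon. Going by the values given here, since the one measured example of this exchange, a 1.2-fold higher number from compound 2 to compound 1 (0.07 log units; within the scatter), stayed within the scatter, a step of similar size is expected, a 1.2-fold higher number from compound 3 to compound 4 (0.07 log units; within the scatter), in this assay. On that basis compound 4 is estimated at 3500 nM, most likely between 1800 nM and 7000 nM.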

Compound 4, half-maximal inhibitory concentration: > 4000 nM
Compound 4: no number, only a limit; the forecaster's own chance of this, stated with the estimate: 0%; middle value at least 1.1-fold (0.05 log units) away from the limit.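

In this assay compound 4 gives > 4000 nM, which is a limit of the assay and not a number. As far as these compounds go, the new step can therefore be read only as a floor, an at least 1.3-fold higher number from compound 3 to compound 4 (0.12 log units; that floor lies within the scatter), and the true size of the change on this core remains unknown. Set side by side, the two cores give no sign that fluoro in place of chloro behaves differently from one core to the other, but they do not prove that it behaves alike either: the same change on two cores in this assay, a 1.2-fold higher number (0.07 log units; within the scatter) from compound 2 to compound 1 and an at least 1.3-fold higher number (0.12 log units; that floor lies within the scatter) from compound 3 to compound 4; the limit leaves it open whether they differ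

The compounds shown carry only chloro or fluoro on the aniline ring, always on the same aromatic carbon, so it remains open how a bromo, a methoxy group, a nitrile or an amine at that place would read on either core. From the compounds shown here alone, with a single cell assay and one limit among the values, it also remains open whether the two cores would stay this close with other groups or in other cells.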